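Swapping Benzamido for (2-Chlorobenzyl)oxy on a Shared Core

A few compounds are considered here, and "the series" means these few. Any claim that something is new, unique, unknown or untested is made for them only; others in the source may bear on it.

Compound 1, `Cc1nn(-c2ncnc3nc[nH]c23)c2c1C(c1ccc(OC(C)C)cc1)CC(=O)N2`: in a functional assay on HEK293 cells for agonist activity at G-protein coupled receptor 39 (Homo sapiens), read by scintillation proximity assay and inositol phosphate accumulation, with a stated time of 75 min, in the presence of a further agent that is not named here (on this read-out higher numbers stand for an effect only at larger amounts of compound and lower numbers for an effect already at smaller amounts), compound 1 gives 18 nM.
Compound 2, `Cc1nn(-c2ncnc3nc[nH]c23)c2c1C(OCc1ccc(C#N)cc1)CC(=O)N2`: in this assay compound 2 gives 4 nM.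
Compound 3, `Cc1nn(-c2ncnc3nc[nH]c23)c2c1C(NC(=O)c1ccccc1)CC(=O)N2`: in this assay compound 3 gives 3 nM.

Compound 3 holds the lowest number of the three, but the step of a 1.3-fold lower number from compound 2 to compound 3 (0.12 log units; within the scatter) lies within the scatter, so compound 2 and compound 3 cannot be ranked against each other. Against compound 1 the gap is clearer: a 6.0-fold lower number from compound 1 to compound 3 (0.78 log units; beyond the scatter).

Compound 4, `Cc1nn(-c2ncnc3nc[nH]c23)c2c1C(OCc1ccccc1Cl)CC(=O)N2`, differs from compound 3 in a single place: (2-chlorobenzyl)oxy in place of benzamido on a saturated ring carbon. The step that bears most on this change is a 1.3-fold lower number from compound 2 to compound 3 (0.12 log units; within the scatter), which showed that a benzyloxy-type group and benzamido at this carbon give essentially the same number. Among the measured compounds shown here, compound 4 again carries a benzyloxy-type group, though with chlorine at the 2-position of the ring rather than the nitrile of compound 2; no measured step covers that difference in ring substitution. The steps of a 4.5-fold lower number from compound 1 to compound 2 (0.65 log units; beyond the scatter) and a 6.0-fold lower number from compound 1 to compound 3 (0.78 log units; beyond the scatter) show that both replacements of 4-isopropoxyphenyl lowered the number by a modest amount.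

Compound 4 is therefore expected to stay close to compound 3, with a step of a 2.0-fold higher number from compound 3 to compound 4 (0.30 log units; within the scatter), perhaps a slightly higher number. The estimate for compound 4 in this assay is 6 nM, within a range from 2 nM to 20 nM.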

Compound 4, half-maximal effective concentration: 2 nM
Compound 4: the middle estimate sits 3.0-fold (0.48 log units) above what was measured; low and high end bracket the measured number.
By their numbers in this assay, from the lowest: compounds 4, 3 and 2 (each within the scatter of the next); then compound 1.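

In this assay, the step of a 1.5-fold lower number from compound 3 to compound 4 (0.18 log units; within the scatter) shows that this saturated ring carbon tolerates the exchange of benzamido for (2-chlorobenzyl)oxy without a change beyond the scatter, although the entering group has no hydrogen-bond donor and the leaving group has one. Among the compounds shown here, the step of a 2.0-fold lower number from compound 2 to compound 4 (0.30 log units; within the scatter) adds the first reading on the ring of the benzyloxy-type group: 2-chlorophenyl in place of 4-cyanophenyl also stays within the scatter, so these two benzyloxy-type groups cannot be ranked against each other. With a 9.0-fold lower number from compound 1 to compound 4 (0.95 log units; beyond the scatter), a third group in place of 4-isopropoxyphenyl now gives a step beyond the scatter, and none of the three replacements goes against that direction.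

The compounds shown leave open whether an amine, a carboxylic acid or a longer chain on this saturated ring carbon would stay close to compound 2, compound 3 and compound 4, or would move the number away from them. There is no supporting measurement here that explains why these groups give such similar numbers.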